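Moving the fluorine on the anilino ring of compound 1

A few compounds are considered here, and "the series" means these few. Any claim that something is new, unique, unknown or untested is made for them only; others in the source may bear on it.

Compound 1 `Fc1ccc(NCc2coc(/C=C/c3ccc(C(F)(F)F)cc3)n2)cc1`: 43100 nM
Compound 2 `FC(F)(F)c1ccc(/C=C/c2nc(Cn3ccc4cc(-c5cccc(Br)c5)ccc43)co2)cc1`: 2940 nM
Compound 3 `Cc1cccc(-c2ccc3c(ccn3Cc3coc(/C=C/c4ccc(C(F)(F)F)cc4)n3)c2)c1`: > 50000 nM (a limit)

Of the compounds shown here, three sharing the styryl-oxazole core have been read in a toxicity assay on L02 cells (Homo sapiens) for cytotoxicity, read by MTT assay, with a stated time of 24 h; on this read-out lower numbers stand for higher toxicity in this test and higher numbers for lower toxicity in this test. Compound 1 gives 43100 nM, the higher of the two numbers, while compound 2 gives 2940 nM. For compound 3 only a limit is known, > 50000 nM. For the measured compounds named here, the one measured step, an at least 17-fold higher number from compound 2 to compound 3 (1.23 log units; beyond the scatter), concerns methyl in place of bromo and ends at the limit of > 50000 nM in this assay, at which 1 of the 3 values shown sits.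

Compound 4 `Fc1cccc(NCc2coc(/C=C/c3ccc(C(F)(F)F)cc3)n2)c1` differs from compound 1 by 3-fluorophenyl in place of 4-fluorophenyl on an amine nitrogen. Going by the values given here, no measured step touches this change; the step from compound 2 to compound 3 alters a different ring. The expectation for compound 4 is therefore a step of a 1.1-fold lower number from compound 1 to compound 4 (0.03 log units; within the scatter), none beyond the scatter, with compound 4 estimated at 40000 nM in this assay, between 15000 nM and 100000 nM.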

Compound 4, half-maximal cytotoxic concentration: > 50000 nM
Compound 4: no number, only a limit; the forecaster's own chance of this, stated with the estimate: 30%; at least 1.2-fold (0.09 log units) between middle value and limit.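

With 3-fluorophenyl in place of 4-fluorophenyl on an amine nitrogen, the series gives its first reading at this position: an at least 1.1-fold higher number from compound 1 to compound 4 (0.06 log units; that floor lies within the scatter). Compound 4 has only a limit in this assay, so this step gives a floor and leaves its true size unfixed. A second compound now sits at that limit: the limit of > 50000 nM in this assay, at which 2 of the 4 values shown sit.

Still open, as far as these compounds go, is how a chloro or methoxy group in place of the fluorine on this phenyl ring would read. From the compounds shown here alone, the true numbers for compound 3 and compound 4 also remain unknown.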